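Pyridin-4-yl for 3-Methoxyphenyl: An Estimate from Three Measurements

The source may hold more compounds than are shown below. What is called first, only, known or untested is meant among the compounds shown, and "the series" means these compounds.

Compound 1, `CCOC(=O)C1=C(C)N/C(=C/c2cc(C)n(-c3cccc(C(F)(F)F)c3)c2C)C1=O`, gives 3.4 in a physicochemical assay for lipophilicity, read by HPLC, at pH 7.4; on this read-out higher numbers stand for higher lipophilicity and lower numbers for lower lipophilicity.
Compound 2, `CCOC(=O)C1=C(C)N/C(=C/c2cc(C)n(-c3ccc(Cl)cc3)c2C)C1=O`, gives 3.4 in this assay.
Compound 3, `CCOC(=O)C1=C(C)N/C(=C/c2cc(C)n(-c3cccc(OC)c3)c2C)C1=O`, gives 2.9 in this assay.

Among these three, compound 3 stands lowest: the measured step shows a number 0.50 log units lower from compound 1 to compound 3 (beyond the scatter) and likewise a number 0.50 log units lower from compound 2 to compound 3 (beyond the scatter), while between the other two there is no change at the digits printed from compound 1 to compound 2 (within the scatter). Compound 4, `CCOC(=O)C1=C(C)N/C(=C/c2cc(C)n(-c3ccncc3)c2C)C1=O`, differs from compound 3 in one place: pyridin-4-yl in place of 3-methoxyphenyl on an aromatic nitrogen. Within the data shown here, no measured step swaps an aryl ring on that nitrogen for a ring carrying a ring nitrogen, so the closest guides are the two aryl-to-aryl steps already seen, each of modest size in this assay. Given that compound 3 sits at 2.9, and that the only changes on this ring seen so far moved the read-out by half a unit or not at all, compound 4 is expected to fall further, by a step estimated at a number 1.00 log units lower from compound 3 to compound 4 (beyond the scatter). Compound 4 is therefore estimated at 1.9, within a range from 1.3 to 2.5.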

Compound 4, distribution coefficient: 3.2
Beside the measured number, compound 4's estimate is 1.30 log units below it; measured number above the stated range.
By their numbers in this assay, from the lowest: compounds 3, 4, 1 and 2 (each within the scatter of the next, the first and the last beyond it).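

In this assay, pyridin-4-yl on this aromatic nitrogen gives a number 0.30 log units higher from compound 3 to compound 4 (within the scatter) and a number 0.20 log units lower from compound 2 to compound 4 (within the scatter) and a number 0.20 log units lower from compound 1 to compound 4 (within the scatter) in the same reading, so it cannot be told apart from any of the three aryl groups. The earlier compounds shown here had split into two groups at this position, with a number 0.50 log units lower from compound 2 to compound 3 (beyond the scatter) as the measured gap, and compound 4 lies within the scatter of both sides of that gap, so a ring nitrogen in place of a ring carbon shows no separate effect here. Nothing at hand explains this result.

Still open, from the compounds shown here alone, is whether pyridin-3-yl or pyridin-2-yl would read the same as pyridin-4-yl at this position. Also open, going by these compounds, is whether a phenyl ring carrying a carboxylic acid or an amine would move the read-out beyond the scatter.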